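Swapping the side-chain amine: compound 2 to compound 3

The source may hold more compounds than are shown below. What is called first, only, known or untested is meant among the compounds shown, and "the series" means these compounds.

Compound 1 `O=C(NCc1ccc(F)cc1)c1nc(Br)c2cccnc2c1NCc1ccc(F)cc1` carries a fluorine-bearing benzylic group on the amine side of the shared core; in a functional assay on MCF7 cells (Homo sapiens) for cytotoxicity, read by MTT assay, with a stated time of 72 h (on this read-out higher numbers stand for weaker inhibition and lower numbers for stronger inhibition), compound 1 is recorded as "not determined" (no result reported), with no result reported. Compound 2 `CN(C)CCCNc1c(C(=O)NCc2ccc(F)cc2)nc(Br)c2cccnc12` bears an amine chain in that position, and in this assay compound 2 gives 7000 nM. Among the measured compounds shown here, compound 2 thus stands as the only number in hand for the series; compound 1 contributes no value against which it can be placed, so no rank within the set can be assigned.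

Compound 3 `O=C(NCc1ccc(F)cc1)c1nc(Br)c2cccnc2c1N1CCNCC1` has not been measured. Its difference from compound 2 is piperazin-1-yl in place of (3-(dimethylamino)propyl)amino on an aromatic carbon. For the measured compounds named here, no step between two measured compounds exists here, so the size of such a step cannot be read from data. The leaving and entering groups carry the same count of hydrogen-bond donors and acceptors, and the expectation is a step from compound 2 to compound 3 of a 1.1-fold higher number from compound 2 to compound 3 (0.06 log units; within the scatter), within the usual scatter rather than beyond it. Compound 3 is expected to give 8000 nM in this assay, with a likely range from 2500 nM to 25000 nM.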

Compound 3, half-maximal inhibitory concentration: 7000 nM
For compound 3 the middle estimate is 1.1-fold (0.06 log units) above the measured one; low and high end bracket the measured number.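

Among the compounds shown here, the first step that can be read at this position in this assay is no change at the digits printed from compound 2 to compound 3 (within the scatter), with piperazin-1-yl in place of (3-(dimethylamino)propyl)amino on the aromatic carbon para to the bromo group. For this pair, an open chain and a six-membered non-aromatic ring are interchangeable on this read-out, something compound 2 alone could not show, though the finding covers this single change and no wider pattern. Nothing available bears on why the two groups read alike.

Steps involving compound 1 cannot be read, so the fluorine-bearing benzylic group on the amine side of the shared core has no place yet beside the two amines. Also open, going by these compounds, is whether a morpholine ring, with oxygen in place of the second ring nitrogen, or a longer chain ending in the same dimethylamino group would stay within the scatter of compound 2 and compound 3 or move away from them.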